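From compound 2 to compound 3 on the carbonyl carbon

The source may report more compounds than this note shows. Statements on the series, on what has been measured and on what is new or still open speak of the compounds shown alone.

Measured in a functional assay on HepG2 cells (Homo sapiens) for antiproliferative activity, read by MTT assay, with a stated time of 48 h; a higher number here means a weaker inhibitor, a lower number a stronger inhibitor:
compound 1 `COc1ccc(/C=C/c2cc(OC)cc(OC)c2/C=C/C(=O)c2cccc(Cl)c2)cc1`: 9.5 ug/mL
compound 2 `COc1ccc(/C=C/c2cc(OC)cc(OC)c2/C=C/C(=O)c2ccc(C)cc2C)cc1`: 0.9 ug/mL

Compound 2 holds the lower of the two numbers. Next comes compound 3 `CCN(CC)c1ccc(C(=O)/C=C/c2c(/C=C/c3ccc(OC)cc3)cc(OC)cc2OC)cc1`, with this change: 4-(diethylamino)phenyl in place of 2,4-dimethylphenyl on a carbonyl carbon. Among the measured compounds shown here, the only measured step at this place is large and beyond the scatter: an 11-fold lower number from compound 1 to compound 2 (1.02 log units; beyond the scatter). For the measured compounds named here, the entering group has no measured precedent, so the direction remains uncertain. Going by the values given here, with compound 2 at 0.9 ug/mL, the lower number so far, a moderate rise is expected: a 3.3-fold higher number from compound 2 to compound 3 (0.52 log units; beyond the scatter). Compound 3 is estimated at 3 ug/mL, with an expected range of 0.7 ug/mL to 12 ug/mL.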

Compound 3, half-maximal inhibitory concentration: 6.3 ug/mL
For compound 3 the middle estimate is 2.1-fold (0.32 log units) below the measured one; the range from low to high includes it.
By their numbers in this assay, from the lowest: compound 2; then compounds 3 and 1 (each within the scatter of the next).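

In this assay, the low number of compound 2 does not carry over to the 4-(diethylamino)phenyl group on the carbonyl carbon (a 7.0-fold higher number from compound 2 to compound 3 (0.85 log units; beyond the scatter)). Exchanging 3-chlorophenyl for the same group gives a step within the scatter (a 1.5-fold lower number from compound 1 to compound 3 (0.18 log units; within the scatter)), so these two groups cannot be ordered, and 2,4-dimethylphenyl alone stands apart among the three. Nothing available explains either step.

From the compounds shown here alone, it remains open whether both methyl groups of 2,4-dimethylphenyl are needed to keep the low number. A 4-methylphenyl or 2-methylphenyl group would test this, and 4-(dimethylamino)phenyl would show how the amine's chain length matters.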